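This account rests on a few compounds, and the source may have more. Where it says the series, first, only, none or still open, it means among the compounds named here.

Measured so far:
compound 1 `Nc1ccc(/C=C2\SC(=O)N(Cc3ccc(Cl)cc3)C2=O)cc1` — 77000 nM
compound 2 `C=C(Br)C(=O)Nc1ccc(/C=C2\SC(=O)N(Cc3cccc(Cl)c3)C2=O)cc1` — 8900 nM
compound 3 `Nc1ccc(/C=C2\SC(=O)N(Cc3cccc(Cl)c3)C2=O)cc1` — 24000 nM

In a functional assay on HeLa cells (Homo sapiens) for cytotoxicity, read by cell counting, with a stated time of 4 days (on this read-out higher numbers stand for weaker inhibition and lower numbers for stronger inhibition), compound 2 stands lowest of the three, ahead of compound 3 by a 2.7-fold higher number from compound 2 to compound 3 (0.43 log units; beyond the scatter) and well ahead of compound 1. The unmeasured compound 4 `C=C(Br)C(=O)Nc1ccc(/C=C2\SC(=O)N(CC)C2=O)cc1` keeps the (1-bromoethenyl)carbonyl group of compound 2 and changes only the group on the saturated chain carbon bound to the amide-type nitrogen in the ring: methyl in place of 3-chlorophenyl on a saturated chain carbon bound to an amide-type nitrogen in a ring.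

Going by the values given here, no measured pair removes the aromatic ring at that place altogether. The nearest guide is a 3.2-fold lower number from compound 1 to compound 3 (0.51 log units; beyond the scatter), a modest step in this assay, which shows that the substitution pattern of the chlorophenyl group at this position does move the number. Removing the whole 3-chlorophenyl in favour of methyl is a larger change, so the step is expected to be larger and, with nothing in the data to favour a smaller group here, in the direction of a higher number. Compound 4 is therefore estimated at 30000 nM, in a range from 8000 nM to 120000 nM, which means an expected step of a 3.4-fold higher number from compound 2 to compound 4 (0.53 log units; beyond the scatter).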

Compound 4, half-maximal inhibitory concentration: 1400 nM
Beside the measured number, compound 4's estimate is 21-fold (1.33 log units) above it, outside the stated range (below it).
By their numbers in this assay, from the lowest: compound 4; then compound 2; then compound 3; then compound 1.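

In this assay, the 3-chlorophenyl group proves dispensable at this place: with the (1-bromoethenyl)carbonyl group held constant, methyl in place of 3-chlorophenyl on a saturated chain carbon bound to an amide-type nitrogen in a ring gives a 6.4-fold lower number from compound 2 to compound 4 (0.80 log units; beyond the scatter). Going by these compounds alone, the earlier step at this place compared only two chlorophenyl groups, whereas this one shows that the number also moves, and moves downward, when the aromatic ring is gone altogether. Nothing given here accounts for the size or direction of this step.

The compounds shown leave open whether a longer chain such as butyl, or an ethyl group ending in a hydroxyl or an amine, would move the number further. They also leave open whether ethyl has a similar effect when the aromatic amine carries hydrogen in place of (1-bromoethenyl)carbonyl.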